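Acetyl for benzyl on the ring nitrogen of compound 1

The compounds below may be only part of what the source reports. "The series", "measured", "known", "first", "only" and "open" are said of these compounds alone.

Two measured compounds share a core and a butylamino side chain. Compound 1 `CCCCNc1nc(N)nc2c1CCN(Cc1ccccc1)C2` carries a benzyl group on its ring nitrogen; in an assay on HEK293 cells for agonist activity at Toll-like receptor 8 (Homo sapiens), read by a luciferase reporter, with a stated time of 6 h (a higher number here means that more compound is needed for the effect, a lower number that less compound is needed), compound 1 gives 0.4 uM. Compound 2 `CCCCNc1nc(N)nc2c1CN(C)CC2`, with a methyl on its ring nitrogen in a differently arranged core, gives 0.03 uM in this assay. Compound 1 thus stands with the higher of the two numbers, and the gap to compound 2 lies beyond the usual scatter.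

Compound 3 `CCCCNc1nc(N)nc2c1CCN(C(C)=O)C2` is not yet measured. It differs from compound 1 in one place: acetyl in place of benzyl on an amine nitrogen in a ring. Among the compounds with values here, no measured pair follows this exact change, so the direction rests on expectation alone. Since compound 1 gives 0.4 uM, a modest drop in the number is expected, a 1.6-fold lower number from compound 1 to compound 3 (0.20 log units; within the scatter), possibly no larger than the scatter. The expected value for compound 3 in this assay is 0.25 uM, within 0.05 uM to 1.5 uM.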

Compound 3, minimum effective concentration: 0.4 uM
Estimate against measurement, compound 3: 1.6-fold (0.20 log units) below, and the stated range covers the measured number.
By their numbers in this assay, from the lowest: compound 2; then compounds 1 and 3 (each within the scatter of the next).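

Within the data shown here, this is the first step that changes a single place. In this assay, acetyl in place of benzyl on an amine nitrogen in a ring gives no change at the digits printed from compound 1 to compound 3 (within the scatter). On this core, then, the read-out does not separate a group with a six-membered aromatic ring from a smaller group with a carbonyl and one hydrogen-bond acceptor. Nothing measured here explains why the two groups give the same number.

On these data alone, it remains open whether other groups on this nitrogen, such as a methylsulfonyl group or a longer acyl chain like hexanoyl, would also leave the number in place. Compound 2 differs from compound 1 and compound 3 in more than one place, so its lower number cannot be assigned to either its methyl group or its core arrangement.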